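From 3-Fluorophenyl to Phenyl: An Expected Small Step

The source may report more compounds than this note shows. Statements on the series, on what has been measured and on what is new or still open speak of the compounds shown alone.

Compound 1 `COc1cc(/C=C/c2nnc(NC(=O)c3ccc(Cl)cc3)s2)c(Br)c(OC)c1OC`: 280 nM
Compound 2 `COc1cc(/C=C/c2nnc(NC(=O)c3cccc(F)c3)s2)c(Br)c(OC)c1OC`: 340 nM

Among the measured compounds shown here, in a functional assay on MCF7 cells (Homo sapiens) for antiproliferative activity, read by MTT assay, with a stated time of 48 h (on this read-out lower numbers stand for stronger inhibition and higher numbers for weaker inhibition), compound 2 gives 340 nM, which cannot be separated from the only other measured value. Compound 3 `COc1cc(/C=C/c2nnc(NC(=O)c3ccccc3)s2)c(Br)c(OC)c1OC` is related to it by hydrogen in place of fluoro on an aromatic carbon, so that 3-fluorophenyl becomes phenyl. For the measured compounds named here, one measured step bears on this, a swap of the group on the same carbonyl carbon: a 1.2-fold higher number from compound 1 to compound 2 (0.08 log units; within the scatter). Given that small step, the change expected in this assay is a 1.0-fold higher number from compound 2 to compound 3 (0.01 log units; within the scatter), nothing beyond the scatter and with no clear direction. Compound 3 is expected at 350 nM, with an estimated range of 150 nM to 800 nM.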

Compound 3, half-maximal inhibitory concentration: 290 nM
For compound 3 the middle estimate is 1.2-fold (0.08 log units) above the measured one; the measured number falls inside the stated range.
By their numbers in this assay, from the lowest: compounds 1, 3 and 2 (each within the scatter of the next).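

In this assay, a bare phenyl gives the same picture as either halogen-bearing ring: a 1.2-fold lower number from compound 2 to compound 3 (0.07 log units; within the scatter), and a 1.0-fold higher number from compound 1 to compound 3 (0.02 log units; within the scatter). Neither the fluoro of compound 2 nor the chloro of compound 1 is therefore needed for a value in this range. Nothing measured here speaks to why this position tolerates these changes. The compounds shown leave open whether an amine or a carboxylic acid on this ring, or a longer chain in place of the ring, would move the number beyond the scatter.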